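Adding a methylamino group to a poorly soluble thiazole amide

This account rests on a few compounds, and the source may have more. Where it says the series, first, only, none or still open, it means among the compounds named here.

Measured so far:
compound 1, `NCc1csc(NC(=O)c2ncccn2)n1`: > 100 ug/mL
compound 2, `Cc1csc(NC(=O)c2cc(C(C)(C)C)nn2Cc2ccccc2)n1`: < 1.6 ug/mL
compound 3, `NCc1csc(NC(=O)c2ccon2)n1`: 50 ug/mL

Three compounds sharing an amide-linked thiazole core were tested in a physicochemical assay for solubility, read by nephelometry, measured as kinetic solubility, at pH 2.0; on this read-out lower numbers stand for lower solubility and higher numbers for higher solubility. Compound 1 gives > 100 ug/mL, which is a limit of the assay rather than a number. Compound 3 gives 50 ug/mL. Compound 2 gives < 1.6 ug/mL, again a limit and not a number, so compound 2 sits at the limit of < 1.6 ug/mL in this assay, at which 1 of the 3 values shown sits, the low end of what the assay can report.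

Compound 4, `CNCc1csc(NC(=O)c2cc(C(C)(C)C)nn2Cc2ccccc2)n1`, has not been measured. It differs from compound 2 in one place: methylamino in place of hydrogen on a saturated chain carbon bound to an aromatic carbon.

For the measured compounds named here, no step between measured compounds is known, so the expectation for compound 4 rests only on the values above. The step is expected to be upward and clearly beyond the scatter. In this assay compound 4 is expected to give about 40 ug/mL, with a likely range from 6 ug/mL to 150 ug/mL, a rise of an at least 25-fold higher number from compound 2 to compound 4 (1.39 log units; beyond the scatter).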

Compound 4, solubility: 25 ug/mL
Compound 4: middle estimate off by 1.6-fold (0.20 log units), on the high side, and the stated range covers the measured number.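

In this assay, for the compounds shown here, no earlier pair differed in one place, so this is the first direct reading of a single change at this position: methylamino in place of hydrogen on a saturated chain carbon bound to an aromatic carbon gives an at least 15-fold higher number from compound 2 to compound 4 (1.19 log units; beyond the scatter). With the rest of the molecule unchanged, this one change takes compound 4 to 25 ug/mL, away from the low end of what the assay reports. The step's full size stays unknown because the value of compound 2 is a limit and not a number: the limit of < 1.6 ug/mL in this assay, at which 1 of the 4 values shown sits.

Going by these compounds, whether a dimethylamino group, a longer chain ending in an amine or a carboxylic acid at this place would give a similar step stays open. Also open, on these data alone, is whether the same change would give a step of this size with a different group on the amide carbonyl.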